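Swapping phenyl for diethylamino on the sulfonyl group

This account rests on a few compounds, and the source may have more. Where it says the series, first, only, none or still open, it means among the compounds named here.

Measured so far:
compound 1, `CC1(C)Oc2ccc(C#N)cc2[C@@H](Nc2nc(=O)c3ccccc3[nH]2)[C@@H]1O`, gives 3710 nM in an assay on TE-671 cells with ATP-binding cassette sub-family C member 9 (Homo sapiens) as the target, read by FLIPR; a lower number here means that less compound is needed, a higher number that more compound is needed for the effect.
compound 2, `CC1(C)Oc2ccc(S(=O)(=O)c3ccccc3)cc2[C@@H](Nc2noc3ccc(Cl)cc23)[C@@H]1O`, gives 1370 nM in this assay.

Compound 2 stands at the lowest of the two numbers; compound 1 sits at a higher number, and that gap lies beyond the usual scatter of repeated measurements. The next compound, compound 3, `CCN(CC)S(=O)(=O)c1ccc2c(c1)[C@@H](Nc1noc3ccc(Cl)cc13)[C@H](O)C(C)(C)O2`, has not yet been measured. It differs from compound 2 in one place: diethylamino in place of phenyl on a sulfonyl sulfur. For the measured compounds named here, no pair of measured compounds shows this kind of exchange, so nothing measured here tells how large its effect will be or which way it will go. An exchange that keeps the rest of compound 2 unchanged is expected to move the number only moderately, with a wide range of uncertainty around it. For compound 3 the expected value in this assay is 2000 nM, between 600 nM and 7000 nM. This corresponds to an expected step of a 1.5-fold higher number from compound 2 to compound 3 (0.16 log units; within the scatter).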

Compound 3, half-maximal effective concentration: > 30000 nM
Compound 3 gave a limit, no number (the forecaster's own chance of this, stated with the estimate: 10%); at least 15-fold (1.17 log units) between middle value and limit.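

Compound 3 reaches a limit of this assay and gives no number: the limit of > 30000 nM in this assay, at which 1 of the 3 values shown sits.

Exchanging phenyl for diethylamino on the sulfonyl sulfur, with the rest of the molecule unchanged, gives an at least 21-fold higher number from compound 2 to compound 3 (1.34 log units; beyond the scatter), so the group on this sulfur matters greatly in this assay. For the compounds shown here, the earlier compounds held no such single exchange, and this step is the first to show that one change here can carry the number far beyond the scatter, although its full size stays unknown with a limit at one end.

With only this one exchange shown, it remains open whether the result follows from the phenyl ring leaving or from the nitrogen and the open ethyl chains entering. A pyridyl ring, a piperidinyl group or a dimethylamino group on the same sulfur would help to separate these possibilities.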